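The source may hold more compounds than are shown below. What is called first, only, known or untested is meant among the compounds shown, and "the series" means these compounds.

Compound 1 `Cn1c(-c2ccc(NC(=O)CSc3nc4ccccc4o3)cc2)nc(-c2ccccc2)c1-c1ccccc1` in a functional assay on MCF7 cells (Homo sapiens) for cytotoxicity, read by MTT assay, with a stated time of 24 h, tested at 80 ug/mL (on this read-out higher numbers stand for a stronger effect at the one concentration tested and lower numbers for a weaker effect), gives 76.3%.
Compound 2 `Cc1ccc2oc(SCC(=O)Nc3ccc(-c4nc(-c5ccccc5)c(-c5ccccc5)n4C)cc3)nc2c1` gives 65.1%.
Compound 3 `Cn1cnnc1SCC(=O)Nc1ccc(-c2nc(-c3ccccc3)c(-c3ccccc3)n2C)cc1` gives 89.3%.

All three share one core and differ only in the group attached to a sulfur, or in a methyl on that group. Among the three numbers, compound 1 stands second highest. Its nearest neighbour is compound 2, reached by a number 11.2 percentage points lower from compound 1 to compound 2 (beyond the scatter) through a methyl in place of hydrogen on an aromatic carbon. Its furthest neighbour is compound 3, reached by a number 13 percentage points higher from compound 1 to compound 3 (beyond the scatter) when a 4-methyl-4H-1,2,4-triazol-3-yl replaces the 1,3-benzoxazol-2-yl on the sulfur. Between the other two, a number 24.2 percentage points higher from compound 2 to compound 3 (beyond the scatter) points the same way.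

Compound 4 `Cn1c(-c2ccc(NC(=O)CSC3=NCCS3)cc2)nc(-c2ccccc2)c1-c1ccccc1` alters compound 1 at the same sulfur: a group of 5 heavy atoms (3 carbon, 1 nitrogen, 1 sulfur; one five-membered non-aromatic ring with 2 hetero atoms) in place of a group of 9 heavy atoms (7 carbon, 1 nitrogen, 1 oxygen; one five-membered aromatic ring with 2 hetero atoms, one six-membered aromatic ring of carbon only), on a sulfur

The step from compound 1 to compound 3 bears most directly, as it also put a group of fewer heavy atoms in place of the 1,3-benzoxazol-2-yl on that sulfur, with a modest rise; the step from compound 2 to compound 3 agrees in direction. Among the measured compounds shown here, no measured step involves a non-aromatic ring, so the match is loose. A small rise, or no change beyond the scatter, is expected in this assay.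

For compound 4 the estimate is 80%, between 65% and 92%, meaning an expected step of a number 3.7 percentage points higher from compound 1 to compound 4 (within the scatter).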

Compound 4, a percentage reported as activity, at one concentration (the size of the read-out at that concentration, not a potency): 70%
Estimate against measurement, compound 4: 10 percentage points above; the measured number falls inside the stated range.
By their numbers in this assay, from the lowest: compounds 2, 4 and 1 (each within the scatter of the next, the first and the last beyond it); then compound 3.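

In this assay the new five-membered non-aromatic ring on the sulfur gives a number 6.3 percentage points lower from compound 1 to compound 4 (within the scatter) and a number 4.9 percentage points higher from compound 2 to compound 4 (within the scatter) so, despite its fewer heavy atoms, it cannot be told apart on this read-out from either benzoxazole group. Against the triazole the picture differs: a number 19.3 percentage points lower from compound 3 to compound 4 (beyond the scatter) shows that a smaller group on the sulfur does not by itself bring the higher number, and the 4-methyl-4H-1,2,4-triazol-3-yl of compound 3 remains the one group of these four that stands clear of all the others. Nothing available explains why these two small rings part ways.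

Still open, on these data alone, is whether the higher number belongs to the 4-methyl-4H-1,2,4-triazol-3-yl alone, or would also appear with another small aromatic ring such as pyridin-2-yl, or with an open chain on the sulfur such as one ending in a carboxylic acid or an amine. Each compound is also described at a single concentration, so these numbers leave open how the four would rank in potency.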